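Indole halogen swap within a bis-indolyl staurosporine-like series

The source may hold more compounds than are shown below. What is called first, only, known or untested is meant among the compounds shown, and "the series" means these compounds.

Measured so far:
- compound 1 `CO[C@@H]1[C@H](N(C)c2ncc(-c3c[nH]c4ccc(Br)cc34)s2)C[C@H]2O[C@]1(C)n1c3ccccc3c3c4c(c5c6ccccc6n2c5c31)C(=O)NC4`: 410 nM
- compound 2 `CO[C@@H]1[C@H](N(C)c2ncc(-c3c[nH]c4ccc(F)cc34)s2)C[C@H]2O[C@]1(C)n1c3ccccc3c3c4c(c5c6cc(Br)ccc6n2c5c31)C(=O)NC4`: 960 nM

In a functional assay on MV4-11 cells (Homo sapiens) for antiproliferative activity, read by CellTiter-Glo, with a stated time of 72 h (on this read-out higher numbers stand for weaker inhibition and lower numbers for stronger inhibition), compound 1 gives 410 nM, and compound 2 gives 960 nM. Compound 2 therefore stands at the higher of the two numbers, with compound 1 sitting lower by a gap that goes beyond the usual scatter. Going by the values given here, the two compounds differ in two places at once (the halogen on the indole and the substituent on the shared core), so no single-change step between measured compounds exists here.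

Compound 3 `CO[C@@H]1[C@H](N(C)c2ncc(-c3c[nH]c4ccc(Br)cc34)s2)C[C@H]2O[C@]1(C)n1c3ccccc3c3c4c(c5c6cc(Br)ccc6n2c5c31)C(=O)NC4` is the next compound and has not yet been measured in this assay. It differs from compound 2 only in one place: bromo in place of fluoro on an aromatic carbon, on an aromatic carbon of a six-membered aromatic ring of carbon only, part of a fused or bridged system of two rings, meta to a fused ring and para to a fused ring. Compound 1 also carries the bromo on the indole and gives the lower number, but the second difference to compound 2 means that comparison cannot be read as a clean step.

For compound 3 a modest downward step is expected, a 1.6-fold lower number from compound 2 to compound 3 (0.20 log units; within the scatter), with the real chance that it stays within the scatter. The estimate for compound 3 is 600 nM, with a range from 250 nM to 1500 nM.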

Compound 3, half-maximal inhibitory concentration: 390 nM
Compound 3: the middle estimate sits 1.5-fold (0.19 log units) above what was measured, within the range that was stated.
By their numbers in this assay, from the lowest: compounds 3 and 1 (each within the scatter of the next); then compound 2.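

In this assay, the change from 5-fluoro-1H-indol-3-yl to 5-bromo-1H-indol-3-yl can now be read as a single change, with the bromo on the shared core present on both sides: it gives a 2.5-fold lower number from compound 2 to compound 3 (0.39 log units; beyond the scatter) and shows that the identity of the indole halogen registers in this pair. Going by these compounds alone, the bromo on the core can also be read alone for the first time, with 5-bromo-1H-indol-3-yl held constant: bromo in place of hydrogen gives a 1.1-fold lower number from compound 1 to compound 3 (0.02 log units; within the scatter) and so shows no effect that can be separated from the scatter. No measurement at hand accounts for the response to the indole halogen.

Going by these compounds, the indole halogen step rests on this one pair, so whether it holds when hydrogen rather than bromo occupies the core position remains open. Also open, on these data alone, is how chloro, nitrile or methoxy in place of the halogen on the indole would read out, and whether the values would follow any order across these groups.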